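Urea series: chloro for methyl on the aryl ring

The source may report more compounds than this note shows. Statements on the series, on what has been measured and on what is new or still open speak of the compounds shown alone.

Working notes on a small set of aryl ureas sharing one core. Compound 1 `Cc1ccc(NC(=O)Nc2cc(C)nc3ccccc23)cc1` is the reference point. In an ADME assay for permeability, using PAMPA, at pH 7.4 (on this read-out lower numbers stand for lower permeability and higher numbers for higher permeability), compound 1 gives 669 10^-6 cm/s. Compound 2 `Cc1cc(NC(=O)Nc2ccc(F)c(F)c2)c2ccccc2n1` gives 478 10^-6 cm/s in this assay, and compound 3 `CSc1ccccc1NC(=O)Nc1cc(C)nc2ccccc12` gives 1260 10^-6 cm/s in this assay. On these three numbers compound 1 sits in the middle, and both compound 2 and compound 3 lie within the usual scatter of it, so no ordering among the three can be read from the data; all three members sit in a high range of the read-out.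

Compound 4 `Cc1cc(NC(=O)Nc2ccc(Cl)cc2)c2ccccc2n1` has not yet been run in this assay. It differs from compound 1 in one place: chloro in place of methyl on an aromatic carbon. The group sits on an aromatic carbon of a six-membered aromatic ring of carbon only, para to a large group.

Going by the values given here, no step between two measured compounds is available to calibrate this exact change. The other members of the set, compound 2 and compound 3, carry different substituents on that ring and still fall close to compound 1, so a step of about the size of the scatter is expected in this assay, in no clear direction.

Compound 4 is expected to give 720 10^-6 cm/s, with a range from 400 10^-6 cm/s to 1300 10^-6 cm/s. The estimated step of a 1.1-fold higher number from compound 1 to compound 4 (0.03 log units; within the scatter) is expected to stay within the usual scatter.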

Compound 4, apparent permeability: 537 10^-6 cm/s
For compound 4 the middle estimate is 1.3-fold (0.13 log units) above the measured one, and the stated range covers the measured number.
By their numbers in this assay, from the lowest: compounds 2, 4, 1 and 3 (each within the scatter of the next, the first and the last beyond it).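

In this assay, the change from 4-methylphenyl to 4-chlorophenyl gives a 1.2-fold lower number from compound 1 to compound 4 (0.10 log units; within the scatter), so chloro in place of methyl on this aromatic carbon, para to a large group, leaves the read-out within the usual scatter. Going by these compounds alone, this is the first step in the set between two compounds that differ in one place, and it gives the series a direct reading for this position where the earlier compounds offered none. No measurement of any other property accompanies this result, so the size of the step stays a bare observation and nothing can be said about what lies behind it.

The compounds shown leave open how this assay responds at this position to groups of a different kind, such as an amine, a carboxylic acid or a longer chain in place of the methyl. They also leave open whether the same swap of chloro for methyl would stay as small elsewhere on the ring or on a core other than the one shared here.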